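Side-chain change from compound 1 to compound 3

This account rests on a few compounds, and the source may have more. Where it says the series, first, only, none or still open, it means among the compounds named here.

Among the compounds with values here, compound 1 `COc1cc(C(=O)N2CCN(C(=O)c3cc(OC)c(OC)c(OC)c3)C(COC(=O)CC(C)(C)C)C2)cc(OC)c1OC` stands at the lowest number of the two measured members. In a functional assay (Oryctolagus cuniculus) for inhibition of platelet-activating factor receptor (Cavia porcellus) (a lower number here means a stronger inhibitor, a higher number a weaker inhibitor), compound 1 gives 120 nM. Within the data shown here, compound 2 `COc1cc(N2CCN(c3cc(OC)c(OC)c(OC)c3)CC2)cc(OC)c1OC` gives 12500 nM in this assay, a gap to compound 1 that lies well beyond the scatter; no single-point step links these two, so only the two values themselves are known.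

Compound 3 `CCC(CC)NC(=O)OCC1CN(C(=O)c2cc(OC)c(OC)c(OC)c2)CCN1C(=O)c1cc(OC)c(OC)c(OC)c1` differs from compound 1 in one place: (pentan-3-yl)amino in place of neopentyl on a carbonyl carbon. Cut one bond further out, the difference reads neopentylcarbonyl to (pentan-3-yl)carbamoyl. Among the measured compounds shown here, no measured pair shows a step of this kind, so no size can be read off from measured compounds. Because compound 1 gives 120 nM and the change is confined to the end of the side chain, the step of a 1.1-fold lower number from compound 1 to compound 3 (0.04 log units; within the scatter) is expected to be small, within the scatter, with no firm direction. Compound 3 is therefore expected at 110 nM, with a range from 35 nM to 400 nM.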

Compound 3, half-maximal inhibitory concentration: 130 nM
For compound 3 the middle estimate is 1.2-fold (0.07 log units) below the measured one; low and high end bracket the measured number.
By their numbers in this assay, from the lowest: compounds 1 and 3 (each within the scatter of the next); then compound 2.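

In this assay the exchange of neopentyl for (pentan-3-yl)amino on a carbonyl carbon gives a 1.1-fold higher number from compound 1 to compound 3 (0.03 log units; within the scatter), the first step measured at this position. The nitrogen and the hydrogen-bond donor that enter with the (pentan-3-yl)amino group therefore leave the number within the scatter, and neopentylcarbonyl and (pentan-3-yl)carbamoyl cannot be told apart in this read-out. No supporting evidence bears on this result.

Going by these compounds, whether a carboxylic acid, a primary amine or a longer chain on this carbonyl carbon would also stay within the scatter of compound 1 remains open. Also open, on these data alone, is what a plain hydrogen in place of the whole ((neopentylcarbonyl)oxy)methyl group would give on the core of compound 1.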